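The source may hold more compounds than are shown below. What is called first, only, known or untested is meant among the compounds shown, and "the series" means these compounds.

Measured so far in an ADME assay on the whole organism (Mus musculus, strain CD-1) for pharmacokinetics, at a dose of 10 mg/kg by the oral route; a lower number here means that a smaller share of the oral dose reaches the circulation, a higher number that a larger share of the oral dose reaches the circulation (all numbers below from this read-out):
- compound 1 `COc1cc([C@](O)(CCN(C)C)[C@@H](c2cc3cc(Br)ccc3nc2OC)c2cccc(OC)c2F)cc(SC)n1` gives 31% as its value
- compound 2 `COc1cccc([C@H](c2cc3cc(C#N)ccc3nc2OC)[C@@](O)(CCN(C)C)c2cc(SC)nc(SC)c2)c1F` gives 28% as its value
- compound 3 `COc1nc2ccc(C#N)cc2cc1[C@@H](c1cccc(C)c1F)[C@@](O)(CCN(C)C)c1cc(SC)nc(SC)c1` gives 31% as its value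

Compound 3 reads the same as compound 1 at the digits shown, and compound 2 sits within the scatter of compound 3. For the measured compounds named here, the series so far is therefore flat in this assay and offers no clear separation.

Against compound 3, the one change in compound 4 `CCSc1cc([C@](O)(CCN(C)C)[C@@H](c2cc3cc(C#N)ccc3nc2OC)c2cccc(C)c2F)cc(SCC)n1` is a group of 12 heavy atoms (9 carbon, 1 nitrogen, 2 sulfur; one six-membered aromatic ring with 1 hetero atom) in place of a group of 10 heavy atoms (7 carbon, 1 nitrogen, 2 sulfur; one six-membered aromatic ring with 1 hetero atom), on a saturated chain carbon bound to an oxygen on a saturated carbon and two saturated chain carbons and the measured compounds hold no step at this place. Going by the values given here, the only single-place step, a number 3 percentage points higher from compound 2 to compound 3 (within the scatter) for methyl in place of methoxy on an aromatic carbon, concerns a different group and stays within the scatter. It gives no direction for the new change and only a weak hint that single changes in this series move this assay little.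

On these data alone, no step beyond the scatter is expected, and the direction stays open. The expected move is a number 2 percentage points lower from compound 3 to compound 4 (within the scatter) as an estimate, and it is no real trend. For compound 4 the estimated value is 29% with 15% to 43% as the expected range.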

Compound 4, oral bioavailability: 22%
For compound 4 the middle estimate is 7 percentage points above the measured one, and the stated range covers the measured number.
By their numbers in this assay, from the lowest: compounds 4, 2, 1 and 3 (each within the scatter of the next).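

In this assay the saturated chain carbon bound to an oxygen on a saturated carbon and two saturated chain carbons now has a step of its own: the group of 12 heavy atoms in place of the group of 10 heavy atoms gives a number 9 percentage points lower from compound 3 to compound 4 (within the scatter) and so does not separate the two compounds in this read-out. The exchange of one group for the other, both with one six-membered aromatic ring with 1 hetero atom and the same count of nitrogen and sulfur, therefore shows no effect at this place that can be told from the scatter, and a single step sets no direction for size here. No available data bear on the background of this result.

On these data alone, whether a group at this place carrying an amine, a carboxylic acid or a longer chain would give a step beyond the scatter in this assay stays open. For the compounds shown here, also open is whether the same exchange would read alike on compounds with other groups elsewhere on the shared core, since this place has only this one step.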